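Compound 3 to compound 4 on the shared core

A few compounds are considered here, and "the series" means these few. Any claim that something is new, unique, unknown or untested is made for them only; others in the source may bear on it.

In a functional assay on DU-145 cells (Homo sapiens) for cytotoxicity, read by MTT assay (on this read-out lower numbers stand for stronger inhibition and higher numbers for weaker inhibition), compound 1 (`CC(C)=CC[C@@H](OC(=O)CCO)C1=CC(=O)c2c(O)ccc(O)c2C1=O`) gives 55300 nM, compound 2 (`CC(=O)OCCC(=O)O[C@H](CC=C(C)C)C1=CC(=O)c2c(O)ccc(O)c2C1=O`) gives 15700 nM and compound 3 (`CC(C)=CC[C@@H](OC(=O)C1CCOC1)C1=CC(=O)c2c(O)ccc(O)c2C1=O`) gives 47500 nM. Two measured steps place the third of these numbers: a 1.2-fold lower number from compound 1 to compound 3 (0.07 log units; within the scatter), and a 3.0-fold higher number from compound 2 to compound 3 (0.48 log units; beyond the scatter).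

Compound 4 (`CC[C@@](C)(O)CC(=O)O[C@H](CC=C(C)C)C1=CC(=O)c2c(O)ccc(O)c2C1=O`), not yet measured, has 2-hydroxy-2-methylbutyl in place of oxolan-3-yl on a carbonyl carbon.

The closest guide is compound 1, whose 2-hydroxyethyl also holds a hydroxy group and which gives 55300 nM. The exchange of that chain for oxolan-3-yl stayed small: a 1.2-fold lower number from compound 1 to compound 3 (0.07 log units; within the scatter). The steps beyond the scatter both involve the acetyl of compound 2, as in a 3.5-fold lower number from compound 1 to compound 2 (0.55 log units; beyond the scatter), and compound 4 carries no acetyl. No step beyond the scatter is therefore expected in this assay, and no direction is favoured.

The estimate amounts to an expected 1.1-fold higher number from compound 3 to compound 4 (0.02 log units; within the scatter). For compound 4 the estimated value is 50000 nM, with an expected range of 22000 nM to 100000 nM.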

Compound 4, half-maximal inhibitory concentration: 12700 nM
Beside the measured number, compound 4's estimate is 3.9-fold (0.60 log units) above it, outside the stated range (below it).
By their numbers in this assay, from the lowest: compounds 4 and 2 (each within the scatter of the next); then compounds 3 and 1 (each within the scatter of the next).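

In this assay, within the data shown here, the earlier steps beyond the scatter all involved the acetyl of compound 2, but this change reaches the same range with no acetyl present: a 3.7-fold lower number from compound 3 to compound 4 (0.57 log units; beyond the scatter). A hydroxy group on the chain therefore does not fix the number, as compound 1 and compound 4 both carry one and the step between them is large: a 4.4-fold lower number from compound 1 to compound 4 (0.64 log units; beyond the scatter). The 2-hydroxy-2-methylbutyl chain and the 2-acetoxyethyl chain cannot be separated, a 1.2-fold lower number from compound 2 to compound 4 (0.09 log units; within the scatter), and nothing available explains the effect of either chain.

Still open, from the compounds shown here alone, is whether the opposite configuration at the stereocentre of 2-hydroxy-2-methylbutyl would give a similar number. Also open, going by these compounds, is how a longer chain ending in an amine or a carboxylic acid would behave on the same carbonyl carbon.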